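This account rests on a few compounds, and the source may have more. Where it says the series, first, only, none or still open, it means among the compounds named here.

In a functional assay on MCF7 cells (Homo sapiens) for inhibition, read by MTT assay, with a stated time of 72 h (on this read-out lower numbers stand for stronger inhibition and higher numbers for weaker inhibition), three compounds built on a shared core have been measured. Compound 1 `CC(C)[C@H](NC(=O)c1cc(Cl)ccc1OCCNC(=O)O)C(=O)Nc1ccc([N+](=O)[O-])cc1Cl` gives > 10000 nM, a limit of the assay and not a number. Compound 2 `CC(C)[C@H](NC(=O)c1cc(Cl)ccc1OCCCCNC(=O)OC(C)(C)C)C(=O)Nc1ccc([N+](=O)[O-])cc1Cl` gives > 10000 nM, again only a limit. Compound 3 `CC(C)[C@H](NC(=O)c1cc(Cl)ccc1OC1CCN(C(=O)OC(C)(C)C)CC1)C(=O)Nc1ccc([N+](=O)[O-])cc1Cl` gives > 10000 nM, so it too stands only at a limit and has no number of its own.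

Compound 4 `CC(C)[C@H](NC(=O)c1cc(Cl)ccc1OC1CCNCC1)C(=O)Nc1ccc([N+](=O)[O-])cc1Cl` differs from compound 3 by a single change, hydrogen in place of tert-butoxycarbonyl on an amine nitrogen in a ring. Among the measured compounds shown here, only one measured step is available, a step that the two limits leave unreadable from compound 1 to compound 2, and it has no readable size and lies on a chain, not on this ring nitrogen. No size or direction can be drawn from the measured compounds, because the limit of > 10000 nM in this assay, at which 3 of the 3 values shown sit, is all they offer. Compound 1, which carries no tert-butoxycarbonyl, sits at that same limit as compound 3, so the data show no gain tied to the absence of this group.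

The expected change is therefore modest, with only a cautious lean towards stronger inhibition, and is estimated as an at least 1.2-fold lower number from compound 3 to compound 4 (0.09 log units; that floor lies within the scatter). Compound 4 may well return only a limit again. For compound 4 the estimated value is 8000 nM, with an expected range from 2000 nM to 30000 nM.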

Compound 4, half-maximal inhibitory concentration: > 10000 nM
Compound 4 ended at the assay's limit; the forecaster's own chance of this, stated with the estimate: 60%; middle value at least 1.2-fold (0.09 log units) away from the limit.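

Among the compounds shown here, no step from compound 1, compound 2 or compound 3 to compound 4 can be read, because each of the four compounds gives only a limit and not a number: the limit of > 10000 nM in this assay, at which 4 of the 4 values shown sit. The compounds shown leave open how strongly any of them inhibits, and whether hydrogen in place of tert-butoxycarbonyl on the ring nitrogen changes that inhibition at all.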